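The compounds below may be only part of what the source reports. "The series", "measured", "known", "first", "only" and "open" are said of these compounds alone.

Measured so far:
compound 1 `CSc1nc(-c2cccs2)c(C#N)c(=O)n1C`, 83 ug/mL
compound 2 `CCOC(=O)c1cnn(-c2nc(-c3ccc(Cl)cc3)c(C#N)c(=O)n2C)c1N`, 88 ug/mL
compound 3 `Cn1c(NN)nc(-c2ccc(Cl)cc2)c(C#N)c1=O`, 46 ug/mL

All three numbers come from a functional assay on microsomes for inhibition, with a stated time of 1 h; a higher number here means a weaker inhibitor, a lower number a stronger inhibitor. Compound 2 stands at the upper end of the three numbers shown, but the gap to compound 1 and the gap to compound 3 are both within the scatter of repeated measurements, so on this evidence the three compounds are not distinguished from one another.

Compound 4 `CCOC(=O)c1cnn(-c2nc(-c3ccco3)c(C#N)c(=O)n2C)c1N` has not yet been measured. It differs from compound 2 in one place: furan-2-yl in place of 4-chlorophenyl on an aromatic carbon. Among the compounds with values here, no step between two measured compounds covers this change. The nearest comparison is compound 1, which also carries a five-membered aromatic ring with one hetero atom on the shared core and gives 83 ug/mL in this assay, within the scatter of compound 2.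

Expectation: the step of a 1.0-fold lower number from compound 2 to compound 4 (0.02 log units; within the scatter) is estimated to be none beyond the scatter, because compound 1 with its five-membered ring gives 83 ug/mL, in line with compound 2. Compound 4 is therefore expected to give about 85 ug/mL in this assay, in the range 40 ug/mL to 180 ug/mL.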

Compound 4, half-maximal inhibitory concentration: 116 ug/mL
Estimate against measurement, compound 4: 1.4-fold (0.14 log units) below, within the range that was stated.
By their numbers in this assay, from the lowest: compounds 3, 1, 2 and 4 (each within the scatter of the next, the first and the last beyond it).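

In this assay, within the data shown here, this pair gives the first direct reading at the aromatic carbon ortho to the cyano group: a 1.3-fold higher number from compound 2 to compound 4 (0.12 log units; within the scatter). Within the scatter, the read-out therefore does not separate furan-2-yl from 4-chlorophenyl at this position on the shared core, even though the step replaces a six-membered aromatic ring of carbon only with a five-membered aromatic ring with 1 hetero atom, removes the chlorine and adds a hydrogen-bond acceptor. No measured evidence bears on this result, so the step can be recorded only as a comparison of these two groups.

A single step with two aromatic groups does not show how far this position accepts change, and an amine such as morpholin-4-yl or a saturated ring such as cyclohexyl could still move the number beyond the scatter. From the compounds shown here alone, it also remains open whether the same result would hold with another group in place of the ethyl ester, such as a carboxylic acid, elsewhere in compound 2 and compound 4.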